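Trimming the Pendant Ring of a Hydroxamate Stilbene

The source may hold more compounds than are shown below. What is called first, only, known or untested is meant among the compounds shown, and "the series" means these compounds.

The series rests on a shared core carrying a hydroxamic acid, and all three members are judged in a functional assay on HCT-116 cells (Homo sapiens) for antiproliferative activity, read by CellTiter-Glo, with a stated time of 72 h; on this read-out higher numbers stand for weaker inhibition and lower numbers for stronger inhibition. Compound 1 `O=C(NO)c1ccc(/C=C/c2ccnc(-c3cc(F)ccc3O)c2)cc1` gives 2040 nM in this assay. For the measured compounds named here, compound 2 `O=C(NO)c1ccc(/C=C/c2ccnc(-c3cccnc3)c2)cc1` gives 5140 nM in this assay, the highest of the two numbers measured so far, and the step of a 2.5-fold higher number from compound 1 to compound 2 (0.40 log units; beyond the scatter) shows the gap between them.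

Compound 3 `O=C(NO)c1ccc(/C=C/c2ccncc2)cc1` has not yet been measured. Its difference from compound 2 is hydrogen in place of pyridin-3-yl on an aromatic carbon. Going by the values given here, no measured pair shows the loss of a whole ring; the only step on record, a 2.5-fold higher number from compound 1 to compound 2 (0.40 log units; beyond the scatter), shows that swapping one ring for another at this place already moved the number upward. Taking that step as the nearest guide, the removal of the pyridin-3-yl altogether is expected to move the number further in the same direction, and a step of a 1.9-fold higher number from compound 2 to compound 3 (0.29 log units; within the scatter) is estimated. Compound 3 is therefore expected to give 10000 nM in this assay, with a range from 3500 nM to 30000 nM.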

Compound 3, half-maximal inhibitory concentration: 3910 nM
For compound 3 the middle estimate is 2.6-fold (0.41 log units) above the measured one, and the stated range covers the measured number.
By their numbers in this assay, from the lowest: compounds 1, 3 and 2 (each within the scatter of the next, the first and the last beyond it).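

In this assay, hydrogen in place of pyridin-3-yl on this aromatic carbon gives a 1.3-fold lower number from compound 2 to compound 3 (0.12 log units; within the scatter), so taking away the whole six-membered aromatic ring leaves a number that cannot be told from that of compound 2. Hydrogen in place of 5-fluoro-2-hydroxyphenyl gives a 1.9-fold higher number from compound 1 to compound 3 (0.28 log units; within the scatter), so neither pendant ring shown separates from the unsubstituted position in this assay, even though the two rings differ from each other by a 2.5-fold higher number from compound 1 to compound 2 (0.40 log units; beyond the scatter), and that one step beyond the scatter therefore marks a gap between two rings and does not show that a ring at this place is needed or harmful. Nothing on hand explains why the numbers fall as they do.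

Still open, on these data alone, is whether a group of another kind on this aromatic carbon, such as an amine, a carboxylic acid or a longer chain, would move the number beyond the scatter from that of compound 3, in either direction. As far as these compounds go, the three compounds also share the hydroxamic acid and the rest of the core, so whether the same holds with any other group in place of the hydroxamic acid remains unknown.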